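The compounds below may be only part of what the source reports. "The series", "measured", "known", "first", "only" and "open" are said of these compounds alone.

Compound 1, `Cc1ccc(N2C(=O)N/C(=C\c3ccc(O)cc3)C2=O)cc1`, gives 27900 nM in a functional assay on NCI-H292 cells (Homo sapiens) for antiproliferative activity; on this read-out higher numbers stand for weaker inhibition and lower numbers for stronger inhibition.
Compound 2, `COc1cccc(N2C(=O)N/C(=C\c3ccc(O)cc3)C2=O)c1`, reaches only the limit of > 200000 nM in this assay.
Compound 3, `O=C1N/C(=C\c2ccc(O)cc2)C(=O)N1c1cccc(I)c1`, likewise reaches only the limit of > 200000 nM in this assay.

Compound 3 therefore stands at a limit rather than at a number, the position described by the limit of > 200000 nM in this assay, at which 2 of the 3 values shown sit. For the measured compounds named here, its one readable step, an at least 7.1-fold higher number from compound 1 to compound 3 (0.85 log units; beyond the scatter), places it clearly weaker than compound 1, while a step that the two limits leave unreadable from compound 2 to compound 3 cannot be sized because both ends sit at the limit.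

Compound 4, `Cc1cccc(N2C(=O)N/C(=C\c3ccc(O)cc3)C2=O)c1`, differs from compound 3 by methyl in place of iodo on an aromatic carbon. Going by the values given here, no measured step covers this exact exchange. The nearest guide is an at least 7.1-fold higher number from compound 1 to compound 3 (0.85 log units; beyond the scatter), in which a methyl-bearing ring gives a readable number while an iodo-bearing ring ends at the limit, though compound 4 carries its methyl as 3-methylphenyl rather than the 4-methylphenyl of compound 1. Compound 2, with methoxy in the same arrangement, also ends at the limit. The expected step is an at least 1.6-fold lower number from compound 3 to compound 4 (0.22 log units; that floor lies within the scatter), a move back toward a readable number, but with a real chance that only a limit is reported. Compound 4 is estimated at 120000 nM, within 30000 nM to 400000 nM.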

Compound 4, half-maximal inhibitory concentration: > 200000 nM
Compound 4 was reported as a limit; the forecaster's own chance of this, stated with the estimate: 45%; middle value at least 1.6-fold (0.22 log units) from the limit.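

Putting 3-methylphenyl in place of 4-methylphenyl on the amide-type nitrogen gives an at least 7.1-fold higher number from compound 1 to compound 4 (0.85 log units; beyond the scatter) in this assay, so among these compounds the same methyl group gives a readable value only in the arrangement of compound 1, and the place of the group on the ring matters as well as its identity. Compound 4 is reported only as a limit, and it joins compound 2 and compound 3, which carry methoxy and iodo in the same arrangement, so that three different groups now end at that limit: the limit of > 200000 nM in this assay, at which 3 of the 4 values shown sit. The steps among compound 2, compound 3 and compound 4 cannot be read, as both ends of each are limits, and no order among these three groups can be drawn from them.

From the compounds shown here alone, whether methoxy or iodo would give a readable value in the arrangement of compound 1 remains open, so the methyl group of compound 1 cannot yet be told apart from any other group placed there. Going by these compounds, it also remains open how an amine, a carboxylic acid or a longer chain in that place would read in this assay.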